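This account rests on a few compounds, and the source may have more. Where it says the series, first, only, none or still open, it means among the compounds named here.

In a functional assay on HepG2 cells (Homo sapiens) for cytotoxicity, read by MTT assay, with a stated time of 24 h (a higher number here means a weaker inhibitor, a lower number a stronger inhibitor), compound 1 `COc1cc(/C=C2\CN(C)C/C(=C\c3ccc(Br)cc3)C2=O)cc(OC)c1OC` gives 6800 nM and compound 2 `CN1C/C(=C\c2ccc(Cl)cc2)C(=O)/C(=C/c2cccc([N+](=O)[O-])c2)C1` gives 8210 nM, so compound 2 stands within the scatter of compound 1. Compound 3 `CN1C/C(=C\c2cccc(Br)c2)C(=O)/C(=C/c2cccc([N+](=O)[O-])c2)C1` differs from compound 2 in one place, 3-bromophenyl in place of 4-chlorophenyl on a double-bonded chain carbon bound to a double-bonded ring carbon. For the measured compounds named here, no step between measured compounds is available as a guide, so no shift beyond the scatter is expected in this assay. The expected step is small, a 1.1-fold lower number from compound 2 to compound 3 (0.04 log units; within the scatter). The estimate for compound 3 is 7500 nM, with an expected range of 3000 nM to 18000 nM.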

Compound 3, half-maximal inhibitory concentration: 4890 nM
For compound 3 the middle estimate is 1.5-fold (0.19 log units) above the measured one; the measured number falls inside the stated range.
By their numbers in this assay, from the lowest: compounds 3, 1 and 2 (each within the scatter of the next).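

In this assay, for the compounds shown here, the first one-place step, 3-bromophenyl in place of 4-chlorophenyl on a double-bonded chain carbon bound to a double-bonded ring carbon, gives a 1.7-fold lower number from compound 2 to compound 3 (0.23 log units; within the scatter), so this place accepts the exchange without a shift beyond the scatter. The exchange alters both the halogen and its ring position, and this single step cannot separate the two. No measured evidence bears on this result. As far as these compounds go, whether 4-bromophenyl or 3-chlorophenyl would separate the two changes remains open. Also open, from the compounds shown here alone, is whether an aryl group carrying an amine or a carboxylic acid at this place would give a step beyond the scatter.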